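This account rests on a few compounds, and the source may have more. Where it says the series, first, only, none or still open, it means among the compounds named here.

Measured in a functional assay on HL-60 cells (Homo sapiens) for cytotoxicity, read by WST assay, with a stated time of 48 h; on this read-out lower numbers stand for an effect already at smaller amounts and higher numbers for an effect only at larger amounts of compound:
- compound 1 `COCOc1ccccc1C[C@H]1C(=O)OC[C@@H]1Cc1ccccc1`: 76000 nM
- compound 2 `O=C1OC[C@H](Cc2ccccc2O)[C@H]1Cc1ccc(Cl)c(Cl)c1`: 33000 nM

With only these two compounds, the picture is small. Compound 2, at 33000 nM, has the lower of the two numbers, so it shows its effect at the smaller amount. Compound 1, at 76000 nM, lies higher by more than the usual scatter of repeated measurements. The two compounds differ in more than one place, so their gap does not reveal what any single group contributes.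

The next compound to be tested is compound 3 `O=C1OC[C@H](Cc2cccc(F)c2)[C@H]1Cc1ccc(Cl)c(Cl)c1`. It differs from compound 2 in one place, with 3-fluorophenyl in place of 2-hydroxyphenyl on a saturated chain carbon bound to a saturated ring carbon. Among the measured compounds shown here, no measured pair here shows what such a swap does. The expectation in this assay is therefore a step no larger than the scatter, leaning slightly toward a lower number. The estimated change is a 1.3-fold lower number from compound 2 to compound 3 (0.12 log units; within the scatter). For compound 3 the expected value is 25000 nM, with an estimated range from 9000 nM to 70000 nM.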

Compound 3, half-maximal effective concentration: 14000 nM
Compound 3: the middle estimate sits 1.8-fold (0.25 log units) above what was measured, within the range that was stated.
By their numbers in this assay, from the lowest: compound 3; then compound 2; then compound 1.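

In this assay, among the compounds shown here, this swap gives the first reading of a single change, on a saturated chain carbon bound to a saturated ring carbon: a 2.4-fold lower number from compound 2 to compound 3 (0.37 log units; beyond the scatter). The step is modest but beyond the scatter, and it shows that the 2-hydroxyphenyl group, with its hydrogen-bond donor and acceptor, is not required at this position for the effect seen in this pair, since the 3-fluorophenyl group, which has neither, gives the lower number of the two, with compound 3 at 14000 nM. No measurement here explains why the number falls.

The swap changes two things at once, the substituent on the aromatic ring and its location, so this single step cannot show which of them matters, or whether the loss of the hydroxyl group or the arrival of the fluorine counts for more. The compounds shown leave that open, as 3-hydroxyphenyl and 2-fluorophenyl would be needed to separate the two, and they also leave open how a larger group such as 3-methoxyphenyl or a chain ending in an amine would fare at this position.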